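The source may report more compounds than this note shows. Statements on the series, on what has been measured and on what is new or still open speak of the compounds shown alone.

Compound 1 `OCCCCc1cn(CCNc2nonc2/C(=N/O)Nc2ccc(F)c(Br)c2)nn1` carries a 4-hydroxybutyl group on its triazole ring; in an assay on isolated protein for inhibition of Indoleamine 2,3-dioxygenase 1 (Homo sapiens) (on this read-out higher numbers stand for weaker inhibition and lower numbers for stronger inhibition), compound 1 gives 80 nM. Compound 2 `CC(C)(O)c1cn(CCNc2nonc2/C(=N/O)Nc2ccc(F)c(Br)c2)nn1` has a 1-hydroxy-1-methylethyl group in that place and in this assay compound 2 gives 115 nM. The step from one to the other, a 1.4-fold higher number from compound 1 to compound 2 (0.16 log units; within the scatter), lies within the scatter, so compound 2 and compound 1 cannot be told apart on these two numbers.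

Compound 3 `CCC(C)(O)c1cn(CCNc2nonc2/C(=N/O)Nc2ccc(F)c(Br)c2)nn1` differs from compound 2 by methyl in place of hydrogen on a saturated chain carbon, two bonds along the chain from an aromatic carbon and an oxygen on a saturated carbon. Going by the values given here, the only measured step that touches this part of the molecule is a 1.4-fold higher number from compound 1 to compound 2 (0.16 log units; within the scatter), and it stayed inside the scatter even though the whole group was exchanged; a single added methyl is a smaller change than that. The expected step is therefore no change at the digits printed from compound 2 to compound 3 (within the scatter), no direction beyond the scatter. For compound 3 the estimate is 115 nM, with a range from 50 nM to 260 nM.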

Compound 3, half-maximal inhibitory concentration: 53 nM
Compound 3: middle estimate off by 2.2-fold (0.34 log units), on the high side; the range from low to high includes it.
By their numbers in this assay, from the lowest: compounds 3, 1 and 2 (each within the scatter of the next, the first and the last beyond it).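

In this assay, adding one methyl to the saturated chain carbon gives a 2.2-fold lower number from compound 2 to compound 3 (0.34 log units; beyond the scatter). This shows that a change of a single carbon at this position can move the number beyond the scatter, something the earlier exchange of the whole group did not do. The 1-hydroxy-1-methylpropyl and 4-hydroxybutyl groups still cannot be told apart, with a 1.5-fold lower number from compound 1 to compound 3 (0.18 log units; within the scatter), and nothing available explains why the added methyl goes with a lower number.

As far as these compounds go, it remains open whether a longer chain or a cyclopropyl ring at this position would lower the number further or raise it again. Also open, from the compounds shown here alone, is what an amine or a methoxy group in place of the hydroxyl would do to the number.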